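The source may report more compounds than this note shows. Statements on the series, on what has been measured and on what is new or still open speak of the compounds shown alone.

Measured compounds in a functional assay on KB cells (Homo sapiens) for antiproliferative activity, read by MTT assay, with a stated time of 72 h; a higher number here means a weaker inhibitor, a lower number a stronger inhibitor:
- compound 1 `CN(C(=O)c1ccccc1)c1ccc2[nH]c(-c3n[nH]c4ccccc34)cc2n1`: 8580 nM
- compound 2 `CN(c1ccc2[nH]c(-c3n[nH]c4ccccc34)cc2n1)S(=O)(=O)c1ccccc1`: 2400 nM
- compound 3 `COc1ccc(S(=O)(=O)N(C)c2ccc3[nH]c(-c4n[nH]c5ccccc45)cc3n2)cc1`: 22100 nM

Compound 3 stands at the highest number of the three in this assay; compound 1 is the nearest to it, compound 2 the furthest, and both gaps are beyond the scatter. The measured step on the aryl group of the sulfonyl is a 9.2-fold higher number from compound 2 to compound 3 (0.96 log units; beyond the scatter). For comparison, a 3.6-fold lower number from compound 1 to compound 2 (0.55 log units; beyond the scatter) concerns the amide-to-sulfonamide exchange and does not bear directly on the present change.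

Compound 4 `CN(c1ccc2[nH]c(-c3n[nH]c4ccccc34)cc2n1)S(=O)(=O)c1cccc([N+](=O)[O-])c1` differs from compound 3 by 3-nitrophenyl in place of 4-methoxyphenyl on a sulfonyl sulfur. Going by the values given here, the change therefore takes away the 4-methoxyphenyl whose introduction gave a 9.2-fold higher number from compound 2 to compound 3 (0.96 log units; beyond the scatter), and brings in a 3-nitrophenyl for which no measured step exists. Compound 2, with an unsubstituted phenylsulfonyl, is the only anchor for the bare ring. The expectation is that compound 4 falls back toward compound 2 but, with the nitro group untested, not all the way: compound 4 is expected at 4500 nM, within 1300 nM to 15000 nM, which means an expected step of a 4.9-fold lower number from compound 3 to compound 4 (0.69 log units; beyond the scatter).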

Compound 4, half-maximal inhibitory concentration: 5870 nM
Estimate against measurement, compound 4: 1.3-fold (0.12 log units) below; the range from low to high includes it.
By their numbers in this assay, from the lowest: compound 2; then compounds 4 and 1 (each within the scatter of the next); then compound 3.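

In this assay, the sulfonyl sulfur position accepts a second kind of ring substituent, and the number depends on which one is present: 3-nitrophenyl in place of 4-methoxyphenyl gives a 3.8-fold lower number from compound 3 to compound 4 (0.58 log units; beyond the scatter). Against the unsubstituted phenylsulfonyl, nitro in place of hydrogen on an aromatic carbon gives a 2.4-fold higher number from compound 2 to compound 4 (0.39 log units; beyond the scatter), so both substituted rings shown, in compound 3 and compound 4, carry higher numbers than the bare ring of compound 2. No measurement at hand accounts for the difference between these groups.

The exchange from compound 3 to compound 4 alters the substituent and its ring location together, so the two contributions cannot be separated. On these data alone, it remains open how an amine or a carboxylic acid on this ring would read, and whether any substituent gives a lower number than compound 2 (2400 nM).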